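The source may report more compounds than this note shows. Statements on the series, on what has been measured and on what is new or still open speak of the compounds shown alone.

In a functional assay on HCT-116 cells (Homo sapiens) for inhibition, read by MTT assay, with a stated time of 24 h, tested at 5 uM (on this read-out higher numbers stand for more inhibition of growth at the one concentration tested and lower numbers for less inhibition of growth), compound 1, with the structure `CS(=O)(=O)c1ccc(-c2cnc3[nH]cc(-c4nnc(-c5ccc(Cl)cc5)o4)c(=O)c3c2)cc1`, gives 16.4%. Compound 2, `N#Cc1ccc(-c2cnc3[nH]cc(-c4nnc(-c5ccc(Cl)cc5)o4)c(=O)c3c2)cc1`, gives 17.9% in this assay, and compound 3, `O=c1c(-c2nnc(-c3ccc(Cl)cc3)o2)c[nH]c2ncc(-c3cccnc3)cc12`, gives 15.9%. The three numbers sit close together: the step of a number 1.5 percentage points higher from compound 1 to compound 2 (within the scatter), the step of a number 0.5 percentage points lower from compound 1 to compound 3 (within the scatter) and the step of a number 2 percentage points lower from compound 2 to compound 3 (within the scatter) all stay within the scatter of repeated measurement, so no one of the three can be set apart from the others.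

Compound 4, `O=c1c(-c2nnc(-c3ccc(Cl)cc3)o2)c[nH]c2ncc(-c3ccccc3)cc12`, differs from compound 3 in a single place: phenyl in place of pyridin-3-yl on an aromatic carbon, on an aromatic carbon of the shared core, two atoms from the ring nitrogen. The measured steps that bear on this change are the two in which the same aromatic group was swapped, from compound 1 and from compound 2 to compound 3, and both were small. On that basis the step of a number 1.1 percentage points higher from compound 3 to compound 4 (within the scatter) is expected to be no larger than the scatter. For compound 4 the estimated result in this assay is 17%, with a range from 8% to 27%.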

Compound 4, percent growth inhibition at one concentration: 12.3%
Estimate against measurement, compound 4: 4.7 percentage points above; measured number inside the range.
By their numbers in this assay, from the lowest: compounds 4, 3, 1 and 2 (each within the scatter of the next).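

In this assay the change from pyridin-3-yl to phenyl on this aromatic carbon gives a number 3.6 percentage points lower from compound 3 to compound 4 (within the scatter), so the ring nitrogen of the pyridin-3-yl group is not shown to matter here at the one concentration tested. Phenyl without a further group also gives a number 5.6 percentage points lower from compound 2 to compound 4 (within the scatter) and a number 4.1 percentage points lower from compound 1 to compound 4 (within the scatter), so neither the cyano nor the methylsulfonyl group on that ring is shown to change the result, and all four compounds stay level within the scatter. No measurement at hand explains these small steps.

From the compounds shown here alone, it stays open whether an amine, a carboxylic acid or a longer chain on the aromatic ring at this position would move the number beyond the scatter. Also open, going by these compounds, is whether changing the 4-chlorophenyl group at the far end of the molecule would do so.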